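Replacing the 4-cyanophenyl group: a first estimate

The source may hold more compounds than are shown below. What is called first, only, known or untested is meant among the compounds shown, and "the series" means these compounds.

Measured so far in a functional assay on HepG2 cells (Homo sapiens) for antiproliferative activity, read by MTT assay, with a stated time of 72 h; a higher number here means a weaker inhibitor, a lower number a stronger inhibitor

- compound 1 `N#Cc1ccc(/C=N/NC(=O)Nc2ccc(Oc3ccnc4[nH]ccc34)c(F)c2)cc1` gives 850 nM
- compound 2 `O=C(N/N=C/c1ccc([N+](=O)[O-])cc1)Nc1ccc(Oc2ccnc3[nH]ccc23)c(F)c1` gives 3030 nM

Compound 1 holds the lower of the two numbers, which makes it the stronger inhibitor of this pair. The next entry is compound 3 `O=C(N/N=C/c1ccc(F)cc1Cl)Nc1ccc(Oc2ccnc3[nH]ccc23)c(F)c1`, which has 2-chloro-4-fluorophenyl in place of 4-cyanophenyl on a carbon with a double bond to nitrogen. Among the compounds with values here, only one measured step bears on this change. With nitro in place of cyano on an aromatic carbon, the series shows a 3.6-fold higher number from compound 1 to compound 2 (0.55 log units; beyond the scatter), a modest change beyond the scatter. Within the data shown here, that step also removes the cyano group, but no measured compound carries the 2-chloro-4-fluorophenyl group, so it is only a loose guide. A modest step toward a higher number is therefore expected in this assay, though a result within the scatter would not be surprising. The expected step is a 1.8-fold higher number from compound 1 to compound 3 (0.25 log units; within the scatter) and remains an estimate. The estimated value for compound 3 is 1500 nM, with an expected range from 400 nM to 5000 nM until the measurement is available.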

Compound 3, half-maximal inhibitory concentration: 1110 nM
Beside the measured number, compound 3's estimate is 1.4-fold (0.13 log units) above it; the measured number falls inside the stated range.
By their numbers in this assay, from the lowest: compounds 1 and 3 (each within the scatter of the next); then compound 2.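

Within this assay, the nitrile is not required for activity at this position: the series shows a 1.3-fold higher number from compound 1 to compound 3 (0.12 log units; within the scatter) when 4-cyanophenyl gives way to 2-chloro-4-fluorophenyl, a group that carries neither a nitrile nor a nitro group. The same group also separates clearly from 4-nitrophenyl, with a 2.7-fold lower number from compound 2 to compound 3 (0.44 log units; beyond the scatter) on this replacement, so among these three compounds only compound 2 stands apart, and the earlier step can no longer be read as a cost of losing the nitrile as such. No evidence at hand explains either step.

Compound 3 changes the ring in two places at once, so the compounds shown do not separate the contribution of the chlorine from that of the fluorine, or show whether either halogen alone would keep the number level with compound 1. On these data alone, it also remains open how this position responds to a phenyl ring bearing a methoxy group, an amine or a carboxylic acid, or to a ring other than phenyl.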